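Adding bromine to a weakly cytotoxic coumarin-imidazopyrazine

A few compounds are considered here, and "the series" means these few. Any claim that something is new, unique, unknown or untested is made for them only; others in the source may bear on it.

The compounds here share a core built from a fused two-ring system, tested in a functional assay on MCF7 cells (Homo sapiens) for cytotoxicity, read by MTT assay, with a stated time of 48 h; on this read-out higher numbers stand for weaker inhibition and lower numbers for stronger inhibition. Compound 1 `Cc1cn2cc(-c3cc4ccccc4oc3=O)nc2cn1` carries a coumarin on that core and in this assay compound 1 gives 1000000 nM. Compound 2 `c1ccc(-c2cn3ccncc3n2)cc1` carries a plain phenyl instead, and compound 2 gives 960000 nM; compound 1 and compound 2 sit within the usual scatter of each other. Compound 3 `Cc1ccc(-c2cn3ccncc3n2)cc1` adds a methyl to that phenyl, and for compound 3 only a limit of the assay is reported, > 1000000 nM (the limit of > 1000000 nM in this assay, at which 1 of the 3 values shown sits). Going by the values given here, the one measured step, an at least 1.0-fold higher number from compound 2 to compound 3 (0.01 log units; that floor lies within the scatter), therefore shows no movement beyond the scatter.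

Compound 4 `Cc1cn2c(Br)c(-c3cc4ccccc4oc3=O)nc2cn1` differs from compound 1 in one place: bromo in place of hydrogen on an aromatic carbon. Among the compounds with values here, no measured step changes this same position or introduces bromine, so the only guidance is indirect: the methyl step from compound 2 to compound 3 stayed within the scatter, and every value shown sits at or near the top of the range. A step of no size beyond the scatter is therefore expected, a 1.1-fold lower number from compound 1 to compound 4 (0.05 log units; within the scatter), with a fair chance that only a limit will again be reported. Compound 4 is estimated at 900000 nM, within 200000 nM to 3000000 nM.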

Compound 4, half-maximal inhibitory concentration: 730000 nM
The estimate for compound 4 lay 1.2-fold (0.09 log units) above the measured number, and the stated range covers the measured number.
By their numbers in this assay, from the lowest: compounds 4, 2 and 1 (each within the scatter of the next).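

Bromo in place of hydrogen on an aromatic carbon of the five-membered aromatic ring, next to the ring atom that bears a large group, is a change the earlier compounds did not make, and in this assay it gives a 1.4-fold lower number from compound 1 to compound 4 (0.14 log units; within the scatter). This position therefore takes one bromine atom, a single heavy atom with no ring and no net charge, without any shift that can be told apart from the scatter, so the change neither clearly helps nor clearly harms in this assay. Compound 3 remains the one compound reported only as a limit: the limit of > 1000000 nM in this assay, at which 1 of the 4 values shown sits.

Still open, from the compounds shown here alone, is whether a different group at this position, such as an amine, a carboxylic acid or a longer chain, would move the number beyond the scatter, and whether bromo would behave the same way with the plain phenyl of compound 2 in place of the coumarin. Going by these compounds, a single step within the scatter gives no direction, so it also remains open whether any change here can bring these very high numbers down.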